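Lengthening the Methyl on Compound 2: What to Expect

A few compounds are considered here, and "the series" means these few. Any claim that something is new, unique, unknown or untested is made for them only; others in the source may bear on it.

Three compounds share one core and differ only in the halogen on an aromatic carbon. Compound 1 `Cc1cc(F)c(S(C)(=O)=O)cc1C(=O)N=C(N)N` carries fluoro, compound 2 `Cc1cc(Cl)c(S(C)(=O)=O)cc1C(=O)N=C(N)N` chloro and compound 3 `Cc1cc(Br)c(S(C)(=O)=O)cc1C(=O)N=C(N)N` bromo. In a functional assay for inhibition of sodium/hydrogen exchanger (Oryctolagus cuniculus) (a lower number here means a stronger inhibitor, a higher number a weaker inhibitor), compound 1 gives 44 nM, compound 2 gives 25 nM and compound 3 gives 12 nM. Compound 2 thus has the second highest number of the three; it stands nearest compound 1 and furthest from compound 3. The halogen swaps gave a 1.8-fold lower number from compound 1 to compound 2 (0.25 log units; within the scatter), a 2.1-fold lower number from compound 2 to compound 3 (0.32 log units; beyond the scatter) and a 3.7-fold lower number from compound 1 to compound 3 (0.56 log units; beyond the scatter).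

Compound 4 `CCc1cc(Cl)c(S(C)(=O)=O)cc1C(=O)N=C(N)N` keeps the chloro and alters the other substituent instead: methyl in place of hydrogen on a saturated chain carbon bound to an aromatic carbon, so that the methyl of compound 2 becomes an ethyl. None of the three measured steps touches this part of the molecule; all of them swap one halogen for another on an aromatic carbon. The data therefore give no direct guide, and the halogen steps, modest as they are, say nothing about a longer chain. Within the data shown here, the plain expectation is no step in this assay beyond the scatter, in either direction.

Compound 4 is therefore estimated at 25 nM, with a range from 10 nM to 65 nM. That estimate corresponds to an expected change of no change at the digits printed from compound 2 to compound 4 (within the scatter).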

Compound 4, half-maximal inhibitory concentration: 63 nM
Compound 4: middle estimate off by 2.5-fold (0.40 log units), on the low side; low and high end bracket the measured number.
By their numbers in this assay, from the lowest: compound 3; then compounds 2, 1 and 4 (each within the scatter of the next, the first and the last beyond it).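

In this assay the change of methyl to ethyl gives a 2.5-fold higher number from compound 2 to compound 4 (0.40 log units; beyond the scatter) and so shows that this place on the shared core is not indifferent to even a small extension. The halogen swaps had only ever probed the other substituent, and the swap of chloro for bromo gave a 2.1-fold lower number from compound 2 to compound 3 (0.32 log units; beyond the scatter) while the added methyl moves the number the other way, towards a weaker inhibitor, so starting from compound 2 the two kinds of change pull in opposite directions. Nothing measured here explains why a single added methyl on a saturated chain carbon bound to an aromatic carbon has this effect, and that one pair is all there is to go on.

On these data alone, what a longer chain such as propyl, a branched isopropyl or a cyclopropyl ring would do at this place remains open, and so does whether the number keeps climbing as the chain grows or levels off after ethyl. As far as these compounds go, it is also open whether ethyl would carry the same cost with bromo or fluoro in place of chloro, since the step is known only on the chloro compounds.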